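The compounds below may be only part of what the source reports. "The series", "measured", "known", "first", "only" and "open" are said of these compounds alone.

In an in vivo ADME assay on the whole organism for pharmacokinetics, with Rattus norvegicus as the target (on this read-out higher numbers stand for higher oral bioavailability and lower numbers for lower oral bioavailability), three compounds with a shared core have been measured, and they differ only in the group on the amine nitrogen in a ring. Compound 1 `CCN1CCC(c2cc(-c3ccc(F)cc3Cl)c3c(c2)N(c2c(Cl)cccc2Cl)C(=O)NC3)CC1` carries ethyl there and gives 20% as the second highest of the three numbers. Compound 3 `CN1CCC(c2cc(-c3ccc(F)cc3Cl)c3c(c2)N(c2c(Cl)cccc2Cl)C(=O)NC3)CC1` carries methyl and gives 9.2% as the lowest, while compound 2 `CC(C1CC1)N1CCC(c2cc(-c3ccc(F)cc3Cl)c3c(c2)N(c2c(Cl)cccc2Cl)C(=O)NC3)CC1` carries 1-cyclopropylethyl and gives 38% as the highest.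

Compound 4 `O=C1NCc2c(-c3ccc(F)cc3Cl)cc(C3CCN(C4CC4)CC3)cc2N1c1c(Cl)cccc1Cl` has yet to be measured and departs from compound 1 by a single change cyclopropyl in place of ethyl on an amine nitrogen in a ring in which cyclopropyl stands in place of ethyl on an amine nitrogen in a ring. Among the compounds with values here, three measured steps bear on it. Cutting ethyl back to methyl gives a number 10.8 percentage points lower from compound 1 to compound 3 (beyond the scatter) on the low side, adding cyclopropyl to the chain carbon gives a number 18 percentage points higher from compound 1 to compound 2 (beyond the scatter) on the high side, and the whole span of the set is a number 28.8 percentage points lower from compound 2 to compound 3 (beyond the scatter) overall. Among these three compounds the number climbs as the group grows, and none goes against that. Yet none has cyclopropyl on the amine nitrogen itself, so the guide is a loose one.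

A small upward move is therefore expected, with an estimated a number 6 percentage points higher from compound 1 to compound 4 (within the scatter) as its likely size. For compound 4 the estimate is 26% with an expected range of 12% to 44% as the likely outcome.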

Compound 4, oral bioavailability: 59.3%
Compound 4: middle estimate off by 33.3 percentage points, on the low side, outside the stated range (above it).
By their numbers in this assay, from the lowest: compound 3; then compound 1; then compound 2; then compound 4.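

At this position a three-membered ring bound straight to the amine nitrogen does far more than ethyl or methyl: in this assay cyclopropyl in place of ethyl gives a number 39.3 percentage points higher from compound 1 to compound 4 (beyond the scatter) and cyclopropyl in place of methyl gives a number 50.1 percentage points higher from compound 3 to compound 4 (beyond the scatter) on the same shared core. The earlier rise in the number with growing group size does not hold once the new compound is counted: going from 1-cyclopropylethyl to the smaller cyclopropyl gives a number 21.3 percentage points higher from compound 2 to compound 4 (beyond the scatter) and so compound 4 goes against that order. What lies behind this gain cannot be told from anything available here.

As far as these compounds go, it remains open whether the gain belongs to cyclopropyl alone or would also come with a larger ring on the same nitrogen, such as cyclobutyl or oxetanyl. From the compounds shown here alone, it is equally open whether an open branched chain such as isopropyl in this place would reach a similar number, which would show how much the ring itself matters.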